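Swapping pyridyl for methylphenyl on an imidazoline ether

The source may report more compounds than this note shows. Statements on the series, on what has been measured and on what is new or still open speak of the compounds shown alone.

Compound 1, `CC(Oc1ccccc1-c1ccncc1)C1=NCCN1`: < 0.3
Compound 2, `CC(Oc1ccccc1-c1ccccc1)C1=NCCO1`: < 0.3
Compound 3, `CC(Nc1ccccc1-c1ccccc1)C1=NCCN1`: 0.5

In a functional assay on CHO cells for agonist activity at Alpha-2B adrenergic receptor (Homo sapiens) (a lower number here means a smaller maximal response, a higher number a larger maximal response), compound 1 gives < 0.3, which is a limit of the assay and not a number. Compound 2 also reaches only a limit, < 0.3. Within the data shown here, compound 3 is the one compound with a measured number, giving 0.5 in this assay. Compound 1 therefore stands at the floor of what has been seen here, and the evidence on this point is simply (the limit of < 0.3 in this assay, at which 2 of the 3 values shown sit).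

Compound 4, `Cc1ccccc1-c1ccccc1OC(C)C1=NCCN1`, differs from compound 1 in one place: 2-methylphenyl in place of pyridin-4-yl on an aromatic carbon. Among the measured compounds shown here, no measured pair of compounds shows this change by itself, so the size of the step cannot be read off directly. Compound 3 carries a plain phenyl rather than a pyridin-4-yl and gives a number, 0.5, in this assay. Compound 2 carries a plain phenyl too yet reaches only the limit, < 0.3. Taken together these leave the direction open, but a modest rise toward a measurable response is expected, a number at least 0.050 higher from compound 1 to compound 4 (that floor lies within the scatter). Compound 4 is thus estimated to give about 0.35 in this assay, with a range from 0.2 to 0.6.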

Compound 4, intrinsic activity: the largest response reached, as a fraction of the reference agonist's: < 0.3
Compound 4: no number, only a limit; the forecaster's own chance of this, stated with the estimate: 45%; at least 0.050 between middle value and limit.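

Compound 1 and compound 4 both stop at a limit of this assay and give no number, so the step between them cannot be read. The compounds shown leave open whether 2-methylphenyl in place of pyridin-4-yl changes the maximal response at all, and by how much, as most results sit at the same floor: the limit of < 0.3 in this assay, at which 3 of the 4 values shown sit.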